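The compounds below may be only part of what the source reports. "The series", "measured", "known", "first", "only" and "open" are said of these compounds alone.

Compound 1 `Cc1noc(-c2cc3ccccc3[nH]2)n1` in a functional assay on Jurkat cells (Homo sapiens) for antiproliferative activity, read by WST assay, with a stated time of 72 h (a lower number here means a stronger inhibitor, a higher number a weaker inhibitor), gives > 50000 nM, which is a limit of the assay and not a number.
Compound 2 `COc1ccc2[nH]c(-c3nc(C)no3)cc2c1` in this assay gives 19900 nM.
Compound 3 `COc1ccc2[nH]c(-c3nc(-c4ccccc4)no3)cc2c1` in this assay gives > 50000 nM, again a limit rather than a number.

Compound 3 therefore stands at the weak end of what has been measured, at the limit where two of the three values sit (the limit of > 50000 nM in this assay, at which 2 of the 3 values shown sit). Only compound 2 has a real number. The step of an at least 2.5-fold lower number from compound 1 to compound 2 (0.40 log units; beyond the scatter) brought the series from the limit to a measurable value, and the step of an at least 2.5-fold higher number from compound 2 to compound 3 (0.40 log units; beyond the scatter) took it back to the limit.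

Compound 4 `O=[N+]([O-])c1ccc2[nH]c(-c3nc(-c4ccccc4)no3)cc2c1` differs from compound 3 by nitro in place of methoxy on an aromatic carbon. Within the data shown here, no measured step exchanges a methoxy for a nitro, so the two measured steps bear on it only loosely: the step of an at least 2.5-fold lower number from compound 1 to compound 2 (0.40 log units; beyond the scatter) shows that the methoxy on this ring went with a modest gain, while the step of an at least 2.5-fold higher number from compound 2 to compound 3 (0.40 log units; beyond the scatter) shows that the phenyl on the other ring erased that gain. Since compound 3 already sits at the limit, a modest change in either direction would most likely leave compound 4 at the limit as well.

Compound 4 is therefore expected to give about 50000 nM, with a range from 15000 nM to 200000 nM, so the expected step of a number no higher from compound 3 to compound 4 (the limit leaves the size open) is none beyond the scatter.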

Compound 4, half-maximal inhibitory concentration: > 50000 nM
Compound 4: a limit, no number; the forecaster's own chance of this, stated with the estimate: 70%; the middle value lies on the limit itself.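

Compound 4 gives > 50000 nM in this assay, again a limit of the assay and not a number. Among these compounds, compound 3 sits at the same limit, so no step from compound 3 to compound 4 can be read, and compound 4 simply joins it there: the limit of > 50000 nM in this assay, at which 3 of the 4 values shown sit. The compounds shown leave open how strongly either compound acts, and whether nitro in place of methoxy changes that at all.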